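A few compounds are considered here, and "the series" means these few. Any claim that something is new, unique, unknown or untested is made for them only; others in the source may bear on it.

Compound 2 (`COc1ccc(Br)cc1C(=O)Nc1ccc(Sc2nc3ccccc3s2)cc1`) carries a methoxy group and a bromo group on the ring attached to the amide. In an assay for inhibition of HSP60/HSP10 (Homo sapiens), with a stated time of 60 min (a higher number here means a weaker inhibitor, a lower number a stronger inhibitor), compound 2 gives > 100000 nM, which is a limit of the assay and not a number. Compound 1 (`COc1c(Br)cccc1C(=O)Nc1ccc(Sc2nc3ccccc3s2)c(Cl)c1`) stands the same way: in this assay compound 1 gives > 100000 nM, again a limit. Compound 3 (`COc1c(Br)cc(Br)cc1C(=O)Nc1ccc(Sc2nc3ccccc3s2)cc1`) also reaches only a limit: in this assay compound 3 gives > 100000 nM. Three values are shown, and (the limit of > 100000 nM in this assay, at which 3 of the 3 values shown sit). Among the compounds with values here, the single measured change, bromo in place of hydrogen on an aromatic carbon, is a step that the two limits leave unreadable from compound 2 to compound 3.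

Compound 4 (`O=C(Nc1ccc(Sc2nc3ccccc3s2)cc1)c1cccc(Br)c1`) differs from compound 2 as follows: hydrogen in place of methoxy on an aromatic carbon. Within the data shown here, no measured step concerns a methoxy group, and the one step that is measured, a step that the two limits leave unreadable from compound 2 to compound 3, gives no size to lean on. What the three compounds do show is that every change tried so far has left the value at the limit, so no step beyond the scatter is expected in either direction. Compound 4 is therefore expected to sit near 100000 nM, within 20000 nM to 500000 nM. The expected step is a number no higher from compound 2 to compound 4 (the limit leaves the size open).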

Compound 4, half-maximal inhibitory concentration: > 100000 nM
Compound 4 gave a limit, no number (the forecaster's own chance of this, stated with the estimate: 80%); the middle value sits exactly at the limit.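

No size can be read for the change from methoxy to hydrogen between compound 2 and compound 4, since each gives a limit of the assay and not a number: the limit of > 100000 nM in this assay, at which 4 of the 4 values shown sit.

The compounds shown leave open whether any change to this shared structure can give a readable value in this assay, and how much the methoxy and bromo groups contribute.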